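The compounds below may be only part of what the source reports. "The series", "measured", "known", "first", "only" and "open" are said of these compounds alone.

In a functional assay on DU-145 cells (Homo sapiens) for inhibition, read by trypan blue exclusion, with a stated time of 96 h; a lower number here means a stronger inhibitor of growth, a higher number a weaker inhibitor of growth:
- Compound 1 `COc1ccccc1/C=C(/SCc1ccc(F)cc1)C(=O)c1ccc(Br)cc1`: 10000 nM
- Compound 2 `COc1ccccc1/C=C(/SCc1ccc(F)cc1)C(=O)c1ccc(Cl)cc1`: 10000 nM

Compound 2 stands level with compound 1. Compound 3 `O=C(/C(=C\c1c[nH]c2ccccc12)SCc1ccc(F)cc1)c1ccc(Cl)cc1` carries 1H-indol-3-yl in place of 2-methoxyphenyl on a double-bonded chain carbon bound to a double-bonded chain carbon. For the measured compounds named here, the only measured step, no change at the digits printed from compound 1 to compound 2 (within the scatter), is chloro in place of bromo on an aromatic carbon, a different change, so it says little here. Going by the values given here, no step has been measured at this place, so only a moderate and uncertain gain toward stronger inhibition is expected. The expected step is a 2.5-fold lower number from compound 2 to compound 3 (0.40 log units; beyond the scatter). For compound 3 the estimated value is 4000 nM, with an expected range from 500 nM to 15000 nM.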

Compound 3, concentration for 50% growth inhibition: 1000 nM
Compound 3: the middle estimate sits 4.0-fold (0.60 log units) above what was measured; low and high end bracket the measured number.
By their numbers in this assay, from the lowest: compound 3; then compounds 1 and 2 (each within the scatter of the next).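

In this assay, this place on a double-bonded chain carbon proves responsive: 1H-indol-3-yl in place of 2-methoxyphenyl gives a 10-fold lower number from compound 2 to compound 3 (1.00 log units; beyond the scatter). The earlier chloro for bromo exchange left the number unchanged at the digits printed, so this is the first change shown to shift growth inhibition. No available data account for the gain. Still open, on these data alone, is whether 1-methyl-1H-indol-3-yl or plain phenyl would hold this level, and whether bromo in place of chloro stays without effect alongside 1H-indol-3-yl.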